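This account rests on a few compounds, and the source may have more. Where it says the series, first, only, none or still open, it means among the compounds named here.

Measured compounds in an ADME assay on Raji cells (Homo sapiens) for cytotoxicity, read by CellTiter-Glo and resazurin assay, with a stated time of 72 h; a higher number here means that more compound is needed for the effect, a lower number that less compound is needed:

Compound 1, `CCOC(=O)CCCCCOc1cccc(CN(C(=O)c2ccc(-c3ccco3)cc2)C(C)C)c1`; in this assay compound 1 gives only a limit of the assay, > 26000 nM.
Compound 2, `CCOC(=O)CCCCCOc1cccc(CN(C(=O)c2ccc(-c3ccc4c(c3)OCCO4)cc2)C(C)C)c1`; in this assay compound 2 gives only a limit of the assay, > 24400 nM.
Compound 3, `CCOC(=O)CCCCCOc1cccc(CN(C(=O)c2ccc(-c3cccc(C(F)(F)F)c3)cc2)C(C)C)c1`; in this assay compound 3 gives only a limit of the assay, > 26000 nM.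

Compound 3 stands where the whole set stands: no number is known for it, and the other two values are limits as well. Two of the three values sit at the limit of > 26000 nM in this assay, at which 2 of the 3 values shown sit, and one at the limit of > 24400 nM in this assay, at which 1 of the 3 values shown sits. Between the measured compounds there is therefore a step that the two limits leave unreadable from compound 1 to compound 2, a step that the two limits leave unreadable from compound 1 to compound 3 and a step that the two limits leave unreadable from compound 2 to compound 3; none of the three exchanges of the group on the aromatic carbon shows a readable size.

Compound 4, `CCOC(=O)CCCCCOc1cccc(CN(C(=O)c2ccc(-c3ccc(Cl)c(Cl)c3)cc2)C(C)C)c1`, differs from compound 3 by 3,4-dichlorophenyl in place of 3-(trifluoromethyl)phenyl on an aromatic carbon. All three measured steps bear on it, since each exchanges the same group at the same place, and each is unreadable. Nothing among them points to a step beyond the scatter in this assay in either direction.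

For compound 4 a value of 40000 nM is estimated in this assay, with a range from 12000 nM to 150000 nM, most likely reported again as a limit. The step expected is a step that the limit leaves unreadable from compound 3 to compound 4.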

Compound 4, half-maximal effective concentration: > 26000 nM
Compound 4: no number, only a limit; the forecaster's own chance of this, stated with the estimate: 80%; the middle value is on the limit's open side.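

In this assay compound 4 gives > 26000 nM, which is only a limit of the assay. Among the compounds shown here, no step to compound 4 from compound 1, compound 2 or compound 3 can be read. The compounds shown leave open whether exchanging the group on the aromatic carbon changes the half-maximal effective concentration at all.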